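This account rests on a few compounds, and the source may have more. Where it says the series, first, only, none or still open, it means among the compounds named here.

Among the measured compounds shown here, compound 2, with the structure `COC(=O)c1cnc(C(=O)CCc2ccc(Oc3ccccc3)cc2)o1`, is one of two compounds measured so far in an assay for inhibition of Fatty-acid amide hydrolase 1 (Rattus norvegicus); a higher number here means a weaker inhibitor, a lower number a stronger inhibitor. Compound 2 gives 1.7 nM in this assay, the lowest of the two numbers. The other compound, compound 1, with the structure `NC(=O)c1cccc(-c2cnc(C(O)CCc3ccc(-c4ccccc4)cc3)o2)n1`, gives 20000 nM in this assay, a number far higher than that of compound 2 and well beyond the scatter. For the measured compounds named here, no single-point step between these two is drawn here, so only the two values themselves can be compared.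

The next compound to be measured, compound 3, has the structure `O=C(O)c1ccc(-c2cnc(C(=O)CCc3ccc(Oc4ccccc4)cc3)o2)nc1`. It differs from compound 2 in one place, counted as 5-carboxypyridin-2-yl in place of methoxycarbonyl on an aromatic carbon.

Compound 2 is so strong that a modest change in either direction would not be surprising, while a large gain is hard to reach from such a low number. The step from compound 2 to compound 3 is expected to be small, estimated as a 2.9-fold higher number from compound 2 to compound 3 (0.47 log units; beyond the scatter), at most slightly weaker and likely within the scatter. Compound 3 is expected to give about 5 nM in this assay, with a range from 1 nM to 30 nM.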

Compound 3, inhibition constant: 33 nM
For compound 3 the middle estimate is 6.6-fold (0.82 log units) below the measured one; the whole stated range lies below it.
By their numbers in this assay, from the lowest: compound 2; then compound 3; then compound 1.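

Putting 5-carboxypyridin-2-yl in place of methoxycarbonyl on the aromatic carbon next to the ring oxygen weakens inhibition in this assay and gives a 19-fold higher number from compound 2 to compound 3 (1.29 log units; beyond the scatter) as a large step. Among the compounds shown here, this is the first reading at this position, and it shows that the position does respond to the group it carries, while the much larger entering group, with 9 heavy atoms against 4, a six-membered aromatic ring and a hydrogen-bond donor, still leaves compound 3 at 33 nM in this assay. Nothing given here bears on why the number rises.

The step replaces the whole group at once, so it cannot tell how much of the rise belongs to the new ring and how much to the carboxylic acid in place of the methyl ester. A plain pyridin-2-yl group, a 5-(methoxycarbonyl)pyridin-2-yl group or a carboxylic acid placed directly on the same aromatic carbon would be needed to divide the step between those parts.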